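The source may hold more compounds than are shown below. What is called first, only, known or untested is meant among the compounds shown, and "the series" means these compounds.

Going by the values given here, in a functional assay on HeLa cells (Homo sapiens) for cytotoxicity, read by MTT assay, with a stated time of 48 h (on this read-out higher numbers stand for weaker inhibition and lower numbers for stronger inhibition), compound 2 `Cc1ccc(S(=O)(=O)/N=C(/CCNC2=CC(=O)c3ccccc3C2=O)Nc2ccc(F)c(F)c2)cc1` gives 8790 nM, the lowest of the two numbers measured so far. Among the compounds with values here, compound 1 `Cc1ccc(S(=O)(=O)/N=C(/CCNC2=CC(=O)c3ccccc3C2=O)Nc2ccccc2I)cc1` gives 19100 nM, and the only measured step, a 2.2-fold lower number from compound 1 to compound 2 (0.34 log units; beyond the scatter), swaps the whole aryl group on the amine nitrogen. Compound 3 `Cc1ccc(S(=O)(=O)/N=C(/CCNC2=CC(=O)c3ccccc3C2=O)Nc2cc(F)c(F)c(F)c2)cc1` differs from compound 2 by fluoro in place of hydrogen on an aromatic carbon. Within the data shown here, that is a smaller change than the measured step, and no step adding a single fluoro has been measured, so the number expected for compound 3 is about a 1.2-fold lower number from compound 2 to compound 3 (0.07 log units; within the scatter), within the scatter. Compound 3 is therefore estimated at 7500 nM, between 2800 nM and 20000 nM.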

Compound 3, half-maximal inhibitory concentration: 8580 nM
For compound 3 the middle estimate is 1.1-fold (0.06 log units) below the measured one; the measured number falls inside the stated range.
By their numbers in this assay, from the lowest: compounds 3 and 2 (each within the scatter of the next); then compound 1.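

In this assay the fluoro added at this aromatic carbon, ortho to a fluoro group, gives no readable difference (a 1.0-fold lower number from compound 2 to compound 3 (0.01 log units; within the scatter)). The 3,4,5-trifluorophenyl group also keeps the advantage over the 2-iodophenyl group that the 3,4-difluorophenyl group showed (a 2.2-fold lower number from compound 1 to compound 3 (0.35 log units; beyond the scatter)), so a third fluoro neither adds to that advantage nor takes it away. No measurement here explains this result. Still open, on these data alone, is whether a different group on this carbon, such as a methoxy group, an amine or a carboxylic acid, would move the number beyond the scatter.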